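The compounds below may be only part of what the source reports. "The series", "measured", "known", "first", "only" and "open" are said of these compounds alone.

Working notes on the series. The shared core is that of compound 3 `COc1ccc(-c2cc(=O)c3c(OC)cc(OC)cc3n2S(=O)(=O)c2c(F)c(F)c(F)c(F)c2F)cc1`. In a functional assay on KOPN-8 cells (Homo sapiens) for antiproliferative activity, with a stated time of 72 h (a higher number here means that more compound is needed for the effect, a lower number that less compound is needed), compound 3 gives only a limit, > 34400 nM, and no number. Compound 2 `COC(=O)c1cc(=O)c2c(OC)cc(OC)cc2n1C` likewise reaches a limit in this assay, > 19000 nM. Compound 1 `COc1ccc(-c2c(Br)c(=O)c3c(OC)cc(OC)cc3n2S(=O)(=O)c2ccc(OC)cc2)cc1` gives a number in this assay, 2580 nM. Two of the three values shown are thus limits: the limit of > 19000 nM in this assay, at which 1 of the 3 values shown sits, and (the limit of > 34400 nM in this assay, at which 1 of the 3 values shown sits). Within the data shown here, compound 3 stands at one of these limits, and no measured step leads from it to any other compound.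

Compound 4 `COc1ccc(-c2cc(=O)c3c(OC)cc(OC)cc3n2S(=O)(=O)c2ccc(Br)s2)cc1` is not yet measured. The change from compound 3 to compound 4 is 5-bromothiophen-2-yl in place of 2,3,4,5,6-pentafluorophenyl on a sulfonyl sulfur. Among the measured compounds shown here, no measured pair differs in one place, so the data give no size for such a step. Compound 1 shows, with its value in this assay of 2580 nM, that a number can be reached with another group on the sulfonyl sulfur, though that pair differs in more than one place. The step from compound 3 to compound 4 is expected to be an at least 4.3-fold lower number from compound 3 to compound 4 (0.63 log units; beyond the scatter), toward less compound needed. Compound 4 is estimated at 8000 nM, within 1500 nM to 40000 nM, with a fair chance that this assay again reports only a limit.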

Compound 4, half-maximal effective concentration: > 48200 nM
Compound 4 gave a limit, no number; the forecaster's own chance of this, stated with the estimate: 35%; middle value at least 6.0-fold (0.77 log units) from the limit.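

In this assay compound 4 gives only a limit, > 48200 nM. Compound 3 likewise gives only a limit, > 34400 nM, and the step between compound 3 and compound 4 cannot be read. The compounds shown leave open whether any group on the sulfonyl sulfur of the shared core gives a number here.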